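Ether substituent on the shared core: cyclopentyl versus benzyl groups

The source may report more compounds than this note shows. Statements on the series, on what has been measured and on what is new or still open speak of the compounds shown alone.

Measured so far:
compound 1 `Cc1nn(-c2ncnc3nc[nH]c23)c2c1C(OCc1ccc(Cl)cc1Cl)CC(=O)N2`: 243 nM
compound 2 `Cc1nn(-c2ncnc3nc[nH]c23)c2c1C(OC1CCCC1)CC(=O)N2`: 62 nM

Among the compounds with values here, in a functional assay on HEK293 cells for agonist activity at G-protein coupled receptor 39 (Homo sapiens), read by scintillation proximity assay and inositol phosphate accumulation, with a stated time of 75 min (a higher number here means that more compound is needed for the effect, a lower number that less compound is needed), compound 1 gives 243 nM while compound 2 gives 62 nM, the lowest of the two numbers; the change a 3.9-fold lower number from compound 1 to compound 2 (0.59 log units; beyond the scatter) is the only step in hand. Compound 3 `Cc1nn(-c2ncnc3nc[nH]c23)c2c1C(OCc1ccccc1F)CC(=O)N2` differs from compound 2 by 2-fluorobenzyl in place of cyclopentyl on an oxygen on a saturated carbon. Within the data shown here, the one bearing step, compound 1 to compound 2, ran toward a lower number when cyclopentyl replaced 2,4-dichlorobenzyl, so returning to a benzyl group is expected to move the number back up, likely by a modest amount. Compound 3 is therefore estimated at 150 nM (range 50 nM to 450 nM), an expected step of a 2.4-fold higher number from compound 2 to compound 3 (0.38 log units; beyond the scatter).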

Compound 3, half-maximal effective concentration: 78 nM
Compound 3: middle estimate off by 1.9-fold (0.28 log units), on the high side; measured number inside the range.
By their numbers in this assay, from the lowest: compounds 2 and 3 (each within the scatter of the next); then compound 1.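

Benzyl as such does not set the number at this oxygen: in this assay, 2-fluorobenzyl in place of cyclopentyl gives a 1.3-fold higher number from compound 2 to compound 3 (0.10 log units; within the scatter), so compound 3 goes against the contrast suggested by the earlier pair. The ring substituents on the benzyl group separate the two benzyl ethers, with 2-fluorophenyl in place of 2,4-dichlorophenyl giving a 3.1-fold lower number from compound 1 to compound 3 (0.49 log units; beyond the scatter). No evidence on the reason for either step is available.

Still open, going by these compounds, is whether removing the chlorines or adding the fluorine drives that step, which an unsubstituted benzyl would help separate. Also open, on these data alone, is how an ether carrying an amine or a carboxylic acid would read at this position.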